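The compounds below may be only part of what the source reports. "The series", "measured", "known", "first", "only" and "open" are said of these compounds alone.

For the measured compounds named here, compound 3 `N=C(N)c1ccc2cc(-c3cccc(OCCCCOc4ccccc4)c3)oc2c1` stands at the low end of the three numbers measured so far in an ADME assay on L6 cells (Rattus norvegicus) for cytotoxicity, read by resazurin assay, with a stated time of 70 h; a lower number here means a stronger inhibitor, a higher number a weaker inhibitor; compound 3 gives 7600 nM. Compound 1 `N=C(N)c1ccc2cc(-c3cccc(OCCCOc4ccccc4)c3)oc2c1` gives 19800 nM in this assay, and the step from compound 1 to compound 3 reads a 2.6-fold lower number from compound 1 to compound 3 (0.42 log units; beyond the scatter). Compound 2 `CC(C)NC(=N)c1ccc2cc(-c3cccc(OCCCOc4ccccc4)c3)oc2c1` gives 82300 nM, the highest of the three.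

Compound 4 `CC(C)NC(=N)c1ccc2cc(-c3cccc(OCCCCOc4ccccc4)c3)oc2c1` has not yet been measured. It differs from compound 3 in one place: isopropyl in place of hydrogen on an amine nitrogen. Going by the values given here, the one measured step of the same kind is the one from compound 1 to compound 2, which reads a 4.2-fold higher number from compound 1 to compound 2 (0.62 log units; beyond the scatter); that pair shares the shorter linker, whereas compound 3 and compound 4 carry the longer one, so the comparison is the only guide available. On that basis compound 4 is expected to give a higher number in this assay than compound 3, with a step of about a 4.2-fold higher number from compound 3 to compound 4 (0.62 log units; beyond the scatter). The estimate for compound 4 is therefore 32000 nM, with a range from 12000 nM to 85000 nM.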

Compound 4, half-maximal inhibitory concentration: 46500 nM
Compound 4: middle estimate off by 1.5-fold (0.16 log units), on the low side; the measured number falls inside the stated range.
By their numbers in this assay, from the lowest: compound 3; then compound 1; then compounds 4 and 2 (each within the scatter of the next).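

In this assay, isopropyl in place of hydrogen on an amine nitrogen now has a second reading on a second core, a 6.1-fold higher number from compound 3 to compound 4 (0.79 log units; beyond the scatter), so the higher number with this change holds on both cores shown, and the two steps agree: the same change on two cores in this assay, a 4.2-fold higher number (0.62 log units; beyond the scatter) from compound 1 to compound 2 and a 6.1-fold higher number (0.79 log units; beyond the scatter) from compound 3 to compound 4, 1.5-fold (0.17 log units) apart, within the scatter of two such steps. The change of phenoxy to phenoxymethyl gives a 1.8-fold lower number from compound 2 to compound 4 (0.25 log units; within the scatter), so among the isopropyl compounds it cannot be told from the scatter, unlike the step between compound 1 and compound 3. Even so, its two readings differ by no more than two such steps allow: the same change on two cores in this assay, a 2.6-fold lower number (0.42 log units; beyond the scatter) from compound 1 to compound 3 and a 1.8-fold lower number (0.25 log units; within the scatter) from compound 2 to compound 4, 1.5-fold (0.17 log units) apart, within the scatter of two such steps.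

From the compounds shown here alone, whether methyl or cyclopentyl on that nitrogen would shift the number as isopropyl does stays open. So does how a longer chain than that of compound 3 would read.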